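This account rests on a few compounds, and the source may have more. Where it says the series, first, only, none or still open, it means among the compounds named here.

Of the compounds shown here, three that share one core have been measured in an ADME assay on HepG2 cells (Homo sapiens) for cytotoxicity, read by luminescence, CellTiter-Glo and ATP content, with a stated time of 72 h; on this read-out higher numbers stand for an effect only at larger amounts of compound and lower numbers for an effect already at smaller amounts. Compound 1 `COc1ccc(F)cc1CNCCCNc1ccnc2cc(CC(C)C)ccc12` gives 2900 nM. Compound 2 `COc1ccc(F)cc1CNCCCNc1ccnc2cc(Cc3ccc(C#N)cc3)ccc12` gives 6050 nM. Compound 3 `COc1ccc(-c2ccc3c(NCCCNCc4cc(F)ccc4OC)ccnc3c2)cc1` gives 5960 nM. Within the data shown here, on these three numbers compound 3 stands second highest: it lies within the scatter of compound 2, as a 1.0-fold lower number from compound 2 to compound 3 (0.01 log units; within the scatter) shows, while a 2.1-fold higher number from compound 1 to compound 3 (0.31 log units; beyond the scatter) is the one step from it that goes beyond the scatter. The parallel step a 2.1-fold higher number from compound 1 to compound 2 (0.32 log units; beyond the scatter) is of about the same size.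

Compound 4 `COc1ccc(F)cc1CNCCCNc1ccnc2cc(-c3ccc(C(F)(F)F)cc3)ccc12` differs from compound 3 in one place: trifluoromethyl in place of methoxy on an aromatic carbon. Among the measured compounds shown here, no measured step exchanges these two groups, so the change has no direct precedent here. What the three measured steps do show is that altering the side group attached to the core moved the number only modestly at most, and in a 1.0-fold lower number from compound 2 to compound 3 (0.01 log units; within the scatter) a change of the whole side group left it within the scatter. The expectation for compound 4 in this assay is therefore a step within the scatter or only slightly beyond it, with no clear direction. For compound 4 the expected step is a 1.1-fold lower number from compound 3 to compound 4 (0.03 log units; within the scatter). Compound 4 is estimated at 5500 nM, with a range from 2500 nM to 12000 nM.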

Compound 4, half-maximal effective concentration: 5190 nM
The estimate for compound 4 lay 1.1-fold (0.03 log units) above the measured number; measured number inside the range.
By their numbers in this assay, from the lowest: compounds 1, 4, 3 and 2 (each within the scatter of the next, the first and the last beyond it).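

Among these compounds, the exchange of methoxy for trifluoromethyl on this six-membered aromatic ring, which no earlier step tested, gives a 1.1-fold lower number from compound 3 to compound 4 (0.06 log units; within the scatter) in this assay and so does not separate the two groups on this read-out. The 4-(trifluoromethyl)phenyl group also stays close to the 4-cyanobenzyl group, with a 1.2-fold lower number from compound 2 to compound 4 (0.07 log units; within the scatter) as the step, which places compounds 2, 3 and 4 all within the scatter of one another. The earlier steps shown here a 2.1-fold higher number from compound 1 to compound 2 (0.32 log units; beyond the scatter) and a 2.1-fold higher number from compound 1 to compound 3 (0.31 log units; beyond the scatter) lay just beyond the scatter, but a 1.8-fold higher number from compound 1 to compound 4 (0.25 log units; within the scatter) does not, so the gap between the isobutyl group and the larger aromatic side groups looks less firm than before, and compound 4 is the one that goes against it.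

From the compounds shown here alone, whether a carboxylic acid or an amine in place of trifluoromethyl on this ring would move the number beyond the scatter remains open. Nothing shown here explains why these side groups give such similar numbers.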